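The source may report more compounds than this note shows. Statements on the series, on what has been measured and on what is new or still open speak of the compounds shown alone.

Compound 1 `C#CCOc1cc(O)c2c(c1)O[C@H](c1ccc(OC)c(O)c1)CC2=O`: 20900 nM
Compound 2 `COc1ccc([C@@H]2CC(=O)c3c(O)cc(OCc4cn(Cc5cccc(C(F)(F)F)c5)nn4)cc3O2)cc1O`: 19900 nM

In a functional assay on RAW264.7 cells (Mus musculus) for inhibition, read by Griess assay, with stated times of 2 h and 24 h (on this read-out higher numbers stand for weaker inhibition and lower numbers for stronger inhibition), compound 2 gives 19900 nM, within the scatter of compound 1 at 20900 nM. Compound 3 `COc1ccc([C@@H]2CC(=O)c3c(O)cc(OCc4cn(C5CCC5)nn4)cc3O2)cc1O` carries cyclobutyl in place of 3-(trifluoromethyl)benzyl on an aromatic nitrogen. For the measured compounds named here, no measured pair shows what such a swap does. With compound 1 at 20900 nM and compound 2 at 19900 nM despite their different side groups, no step beyond the scatter is expected in this assay. The estimated change is a 1.1-fold higher number from compound 2 to compound 3 (0.02 log units; within the scatter), in no firm direction. For compound 3 the estimate is 21000 nM, with an expected range of 8000 nM to 50000 nM.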

Compound 3, half-maximal inhibitory concentration: 15300 nM
The estimate for compound 3 lay 1.4-fold (0.14 log units) above the measured number, within the range that was stated.
By their numbers in this assay, from the lowest: compounds 3, 2 and 1 (each within the scatter of the next).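

In this assay, cyclobutyl in place of 3-(trifluoromethyl)benzyl on the aromatic nitrogen gives a 1.3-fold lower number from compound 2 to compound 3 (0.11 log units; within the scatter), so at this position a four-membered non-aromatic ring and a benzyl group carrying a six-membered aromatic ring read alike. Setting 1-cyclobutyl-1H-1,2,3-triazol-4-yl in place of ethynyl gives a 1.4-fold lower number from compound 1 to compound 3 (0.14 log units; within the scatter), so this exchange also leaves the number within the scatter. Nothing on hand accounts for these readings. As far as these compounds go, whether an amine, a carboxylic acid or a longer alkyl chain on this aromatic nitrogen would shift the number beyond the scatter stays open.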